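The source may report more compounds than this note shows. Statements on the series, on what has been measured and on what is new or still open speak of the compounds shown alone.

Measured compounds:
compound 1, `O=c1cc(Cn2cc(CCCO)nn2)c2ccc(O)cc2o1`, 90200 nM
compound 2, `CCCCCCc1cn(Cc2cc(=O)oc3cc(O)ccc23)nn1`, 59000 nM
compound 3, `O=c1cc(Cn2cc(CCc3ccccc3)nn2)c2ccc(O)cc2o1`, 35100 nM

All three share one core and differ only in the group carried on the chain attached to the five-membered ring. In a functional assay on HeLa cells (Homo sapiens) for inhibition, read by MTT assay, with a stated time of 72 h (on this read-out lower numbers stand for stronger inhibition and higher numbers for weaker inhibition), compound 3 gives the lowest of the three numbers: its distance to compound 2 is within the scatter, so the two cannot be placed in order, while the step of a 2.6-fold lower number from compound 1 to compound 3 (0.41 log units; beyond the scatter) is beyond the scatter and modest in size.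

Compound 4 is `O=c1cc(Cn2cc(CSC(=S)N3CCNCC3)nn2)c2ccc(O)cc2o1`. Relative to compound 3 the change is a group of 9 heavy atoms (5 carbon, 2 nitrogen, 2 sulfur; one six-membered non-aromatic ring with 2 hetero atoms) in place of a group of 7 heavy atoms (7 carbon; one six-membered aromatic ring of carbon only), on a saturated chain carbon bound to an aromatic carbon.

Among the compounds with values here, two measured steps concern the same part of the molecule. The step of a 1.7-fold lower number from compound 2 to compound 3 (0.23 log units; within the scatter) and the step of a 2.6-fold lower number from compound 1 to compound 3 (0.41 log units; beyond the scatter) both replaced a chain-borne group with phenyl. Compound 1, whose chain ends in a hydroxy group, gave 90200 nM, the highest number shown. The group entering in compound 4 again brings a hydrogen-bond donor and several acceptors in place of an all-carbon ring, so a move back toward higher numbers is expected, though the entering group is unlike anything measured and the expectation is loose.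

Compound 4 is therefore expected to give 70000 nM, with a range from 30000 nM to 160000 nM. The expected step of a 2.0-fold higher number from compound 3 to compound 4 (0.30 log units; within the scatter) would be small and could fall within the scatter.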

Compound 4, half-maximal inhibitory concentration: > 100000 nM
Compound 4: only a limit was reported; the forecaster's own chance of this, stated with the estimate: 15%; at least 1.4-fold (0.15 log units) between middle value and limit.
By their numbers in this assay, from the lowest: compounds 3, 2 and 1 (each within the scatter of the next, the first and the last beyond it). At a limit, above all of these: compound 4.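

In this assay compound 4 gives > 100000 nM, which is a limit and not a number: the limit of > 100000 nM in this assay, at which 1 of the 4 values shown sits.

A ring at this place, on a saturated chain carbon bound to an aromatic carbon, therefore does not by itself keep the number low, for a six-membered ring is present on both sides of the step of an at least 2.8-fold higher number from compound 3 to compound 4 (0.45 log units; beyond the scatter). The steps from the two compounds with no ring in the group are an at least 1.6-fold higher number from compound 2 to compound 4 (0.22 log units; that floor lies within the scatter) and an at least 1.1-fold higher number from compound 1 to compound 4 (0.04 log units; that floor lies within the scatter); both floors lie within the scatter, so these steps alone do not set compound 4 clearly apart from either compound, although the true gaps may be larger.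

The new group differs from benzyl in its ring, its two sulfur atoms and its double bond all at once, so the compounds shown leave open which of these parts goes with the higher number. From the compounds shown here alone, a cyclohexyl group or a piperidine ring on the same chain carbon, without the sulfur atoms, would help to separate these parts, and how far compound 4 really lies from compound 3 also remains open.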